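A few compounds are considered here, and "the series" means these few. Any claim that something is new, unique, unknown or untested is made for them only; others in the source may bear on it.

Three compounds share one core and differ only in the halogen or alkoxy groups on their two aromatic rings. Compound 1 `CC1CCN(c2c(S(=O)(=O)c3ccc(F)c(Cl)c3)cnc3cc(Cl)ccc23)CC1` gives 94% in an assay on isolated protein for displacement of a labelled ligand from metabotropic glutamate receptor 5 (Homo sapiens), with a stated time of 60 min, tested at 1 uM; on this read-out higher numbers stand for more inhibition at the one concentration tested (going by the name of the read-out) and lower numbers for less inhibition. Compound 2 `COc1ccc(S(=O)(=O)c2cnc3cc(Cl)ccc3c2N2CCC(C)CC2)cc1Cl` gives 93% in this assay, and compound 3 `CC1CCN(c2c(S(=O)(=O)c3ccc(F)c(Cl)c3)cnc3cc(F)ccc23)CC1` gives 94% in this assay. Compound 3 therefore stands level with compound 1 at the digits shown, the two together the highest of the three numbers, and the only other measured step from compound 1 runs a number 1 percentage points lower from compound 1 to compound 2 (within the scatter), so all three sit inside the usual scatter of one another.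

Compound 4 `CC1CCN(c2c(S(=O)(=O)c3ccc(F)cc3)cnc3cc(F)ccc23)CC1` is the next step from compound 3. The change is hydrogen in place of chloro on an aromatic carbon.

Going by the values given here, two measured steps bear on it, though neither is the same change. Exchanging a group on the same ring gave a number 1 percentage points lower from compound 1 to compound 2 (within the scatter), and exchanging chloro for fluoro on the core gave no change at the digits printed from compound 1 to compound 3 (within the scatter); both stayed within the scatter. Among the compounds with values here, removing a chloro group outright has no direct precedent here. Compound 4 is thus expected to show no step beyond the scatter, perhaps a small drift downward, a number 6 percentage points lower from compound 3 to compound 4 (within the scatter), so that compound 4 is estimated at 88%, between 70% and 97%.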

Compound 4, a percentage reported as inhibition, at one concentration (the size of the read-out at that concentration, not a potency): 74.5%
Estimate against measurement, compound 4: 13.5 percentage points above; low and high end bracket the measured number.
By their numbers in this assay, from the lowest: compound 4; then compounds 2, 1 and 3 (each within the scatter of the next).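

In this assay, going by these compounds alone, hydrogen in place of chloro on the 3-chloro-4-fluorophenyl group gives a number 19.5 percentage points lower from compound 3 to compound 4 (beyond the scatter) and is the first change in this set to pass beyond the scatter. The two earlier steps, a number 1 percentage points lower from compound 1 to compound 2 (within the scatter) and no change at the digits printed from compound 1 to compound 3 (within the scatter), both left this chloro group in place, so they could not show that the reading depends on it; this single pair shows that it does, at least on the shared core with the fluoro group that compound 3 and compound 4 both carry. No measurement here accounts for the loss at this position.

As far as these compounds go, whether another small group at this place, such as bromo, methyl or a nitrile, would hold the reading near that of compound 3 or fall with compound 4 remains open. Also open, from the compounds shown here alone, is whether removing the same chloro group would cost as much with the chloro-bearing core of compound 1, and how far a reading at one concentration reflects any change in potency.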